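Plain phenyl in place of the pyrimidine ring at sulfur

The source may hold more compounds than are shown below. What is called first, only, known or untested is meant among the compounds shown, and "the series" means these compounds.

Three measured compounds share one core and differ only in the group carried on the sulfur. Compound 1 `CC(Sc1nc2c(cnn2C)c(=O)n1-c1ccccc1)c1cccnc1` bears pyridin-3-yl on the saturated chain carbon, compound 2 `CC(Sc1nc2c(cnn2C)c(=O)n1-c1ccccc1)c1cccc(O)c1` bears 3-hydroxyphenyl there, and compound 3 `CC(Sc1nc2c(cnn2C)c(=O)n1-c1ccccc1)c1cncnc1` bears pyrimidin-5-yl. In an assay on PEO1 cells for inhibition of Retinaldehyde dehydrogenase 3 (Homo sapiens), read by flow cytometry, with a stated time of 30 min, tested at 1 uM (on this read-out higher numbers stand for more inhibition at the one concentration tested (going by the name of the read-out) and lower numbers for less inhibition), compound 1 gives 95% and compound 2 gives 61%, while compound 3 gives 39%, the lowest of the three. The steps reaching compound 3 are a number 56 percentage points lower from compound 1 to compound 3 (beyond the scatter) and a number 22 percentage points lower from compound 2 to compound 3 (beyond the scatter), so each exchange of the ring at this position has moved the number well beyond the scatter.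

Compound 4 `C[C@H](Sc1nc2c(cnn2C)c(=O)n1-c1ccccc1)c1ccccc1` introduces the change (1-phenylethyl in place of 1-(pyrimidin-5-yl)ethyl on a sulfur). Among the measured compounds shown here, no measured step covers the phenyl ring itself, yet both steps into compound 3 show its number as the lowest of the three, with compound 2 and compound 1 giving higher numbers after different rings at the same place. The change is therefore expected to raise the number, with a step estimated as a number 36 percentage points higher from compound 3 to compound 4 (beyond the scatter). For the measured compounds named here, compound 4 is expected to reach about 75%, within a range from 45% to 98%, the range being wide since none of the measured compounds carries a defined stereocentre.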

Compound 4, a percentage reported as inhibition, at one concentration (the size of the read-out at that concentration, not a potency): 2%
Beside the measured number, compound 4's estimate is 73 percentage points above it; measured number below the stated range.
By their numbers in this assay, from the lowest: compound 4; then compound 3; then compound 2; then compound 1.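

In this assay, among the compounds shown here, the 1-phenylethyl group, the only group on the sulfur here built of carbon alone, gives the lowest number of the four compounds, with a number 37 percentage points lower from compound 3 to compound 4 (beyond the scatter), a number 59 percentage points lower from compound 2 to compound 4 (beyond the scatter) and a number 93 percentage points lower from compound 1 to compound 4 (beyond the scatter). For the compounds shown here, all three groups holding a nitrogen or an oxygen atom therefore stand above it, which the earlier compounds could not show, although compound 4 also differs from them in carrying one defined stereocentre, so the change of ring and the change in stereocentre cannot be told apart. Nothing available here accounts for the size of this drop.

The compounds shown leave open whether the other mirror-image form of compound 4 would give a similar number, and whether the same ring change would have the same effect with a defined stereocentre in compound 1, compound 2 or compound 3. They also leave open how a phenyl ring bearing an amine or a carboxylic acid, or a longer chain in place of the ethyl link to the sulfur, would fare.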